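The source may hold more compounds than are shown below. What is called first, only, known or untested is meant among the compounds shown, and "the series" means these compounds.

- Compound 1 `CCC(C)n1ncn(-c2ccc(N3CCN(c4ccc(OC[C@@H]5CO[C@@](Cn6cnc(C)n6)(c6ccc(Cl)cc6Cl)O5)cc4)CC3)cc2)c1=O`: 272 nM
- Compound 2 `CCC(C)n1ncn(-c2ccc(N3CCN(c4ccc(OC[C@@H]5CO[C@@](Cn6ccnc6C)(c6ccc(Cl)cc6Cl)O5)cc4)CC3)cc2)c1=O`: 173 nM
- Compound 3 `CCC(C)n1ncn(-c2ccc(N3CCN(c4ccc(OC[C@@H]5CO[C@@](Cn6cc(C(F)(F)F)nc6C)(c6ccc(Cl)cc6Cl)O5)cc4)CC3)cc2)c1=O`: not yet measured

In a functional assay on HUVEC cells (Homo sapiens), read by scintillation counting and thymidine incorporation, with a stated time of 24 h (on this read-out higher numbers stand for weaker inhibition and lower numbers for stronger inhibition), compound 2 gives 173 nM and compound 1 gives 272 nM, so the two stand within the scatter of each other. Compound 3 carries 2-methyl-4-(trifluoromethyl)-1H-imidazol-1-yl where compound 2 carries 2-methyl-1H-imidazol-1-yl: trifluoromethyl in place of hydrogen on an aromatic carbon. In short, trifluoromethyl stands in place of hydrogen on an aromatic carbon.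

Within the data shown here, only one measured step bears on this change. That step, a 1.6-fold lower number from compound 1 to compound 2 (0.20 log units; within the scatter), put 2-methyl-1H-imidazol-1-yl in place of 3-methyl-1H-1,2,4-triazol-1-yl on the same saturated chain carbon, and it stayed within the scatter. Among the measured compounds shown here, no measured step adds trifluoromethyl, so the evidence is indirect and the range must stay wide. In this assay no shift beyond the scatter is expected, with at most a slight lean towards a higher number. The expected change is a 1.3-fold higher number from compound 2 to compound 3 (0.12 log units; within the scatter). Compound 3 is estimated at 230 nM, with an expected range from 90 nM to 580 nM.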

Compound 3, half-maximal inhibitory concentration: 441 nM
Estimate against measurement, compound 3: 1.9-fold (0.28 log units) below, within the range that was stated.
By their numbers in this assay, from the lowest: compounds 2, 1 and 3 (each within the scatter of the next, the first and the last beyond it).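

In this assay the step of a 2.5-fold higher number from compound 2 to compound 3 (0.41 log units; beyond the scatter) is the first among these compounds to lie beyond the scatter, if only modestly, so this aromatic carbon of the 2-methyl-1H-imidazol-1-yl group is not indifferent to what it carries: trifluoromethyl in place of hydrogen moves the number upward. The other new step, a 1.6-fold higher number from compound 1 to compound 3 (0.21 log units; within the scatter), stays within the scatter, so this assay does not separate the 2-methyl-4-(trifluoromethyl)-1H-imidazol-1-yl group from the 3-methyl-1H-1,2,4-triazol-1-yl group, even though the hydrogen-bearing imidazole and the substituted one stand apart. Nothing measured here explains why the number shifts at this carbon.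

From the compounds shown here alone, this rests on a single substitution at one carbon, so it remains open whether the shift belongs to trifluoromethyl itself or would also appear with a methyl, a chlorine or a nitrile in the same place. Going by these compounds, it is equally open whether an amine or a carboxylic acid on this carbon would leave the number where compound 2 stands or carry it in the other direction.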